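One Amide Substituent Changed, Cytotoxicity Still Unmeasured

This account rests on a few compounds, and the source may have more. Where it says the series, first, only, none or still open, it means among the compounds named here.

Measured in a functional assay on A549 cells (Homo sapiens) for cytotoxicity, read by WST assay, with a stated time of 72 h; on this read-out higher numbers stand for weaker inhibition and lower numbers for stronger inhibition:
- compound 1 `COc1cc2c(Nc3nc4ccc(C(=O)Nc5c(C)cc(C)cc5C)cc4s3)ncnc2cc1OCCCN1CCC(C)CC1`: 5400 nM
- compound 2 `COc1cc2c(Nc3nc4ccc(C(=O)Nc5c(C)cccc5C)cc4s3)ncnc2cc1OCCCN1CCCC1`: 83800 nM
- compound 3 `COc1cc2c(Nc3nc4ccc(C(=O)Nc5c(C)cccc5C)cc4s3)ncnc2cc1OCCCN1CCCCC1`: > 100000 nM, a limit of the assay and not a number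

Of the two true numbers in this assay, the lower belongs to compound 1, at 5400 nM, and the higher to compound 2, at 83800 nM. Compound 1 and compound 2 differ in more than one place, so these values show only the gap between them.

Compound 4 `COc1cc2c(Nc3nc4ccc(C(=O)Nc5c(C)cccc5Cl)cc4s3)ncnc2cc1OCCCN1CCC(C)CC1` is compound 1 with 2-chloro-6-methylphenyl in place of 2,4,6-trimethylphenyl on an amide-type nitrogen.

Among the compounds with values here, the only measured step between compounds differing in one place is an at least 1.1-fold higher number from compound 2 to compound 3 (0.07 log units; that floor lies within the scatter). It swaps pyrrolidin-1-yl for piperidin-1-yl, elsewhere in the molecule, and its size is only a floor. Within the data shown here, no measured step touches the group that changes here, so no shift beyond the usual scatter can be predicted, and the expectation stays anchored on compound 1 at 5400 nM. The expected step is a 1.5-fold higher number from compound 1 to compound 4 (0.17 log units; within the scatter), with a slight lean towards a higher number and wide uncertainty. For compound 4 the estimated value is 8000 nM, with an expected range from 1500 nM to 40000 nM.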

Compound 4, half-maximal inhibitory concentration: 9700 nM
For compound 4 the middle estimate is 1.2-fold (0.08 log units) below the measured one; low and high end bracket the measured number.
By their numbers in this assay, from the lowest: compounds 1 and 4 (each within the scatter of the next); then compound 2. At a limit, above all of these: compound 3.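

In this assay, putting 2-chloro-6-methylphenyl in place of 2,4,6-trimethylphenyl on the amide-type nitrogen gives a 1.8-fold higher number from compound 1 to compound 4 (0.25 log units; within the scatter). This is the first step shown at this position, and it indicates that the aryl group can go from 9 heavy atoms, all carbon, to 8 heavy atoms including 1 chlorine without a change beyond the usual scatter in this read-out. Nothing among the data shown accounts for this outcome or ties it to any property of either group.

The two aryl groups compared both keep a methyl group and a six-membered aromatic ring of carbon only, so the compounds shown leave open whether a plain phenyl, a pyridyl ring, or an aryl group bearing an amine or a carboxylic acid on this amide-type nitrogen would also stay within the scatter. They also leave open whether a morpholine in place of the saturated amine ring on the chain would shift the value of compound 4 in this assay.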